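A few compounds are considered here, and "the series" means these few. Any claim that something is new, unique, unknown or untested is made for them only; others in the source may bear on it.

Series notes. Going by the values given here, compound 1 `CCCCC[Se]c1nc([Se]CCCCC)c2ccccc2n1` is the only member with a numeric result in a functional assay on CCRF-CEM cells (Homo sapiens) for cytotoxicity, read by MTT assay, with a stated time of 72 h; on this read-out higher numbers stand for weaker inhibition of growth and lower numbers for stronger inhibition of growth; there compound 1 gives 65700 nM. Compound 2 `CSc1nc(NCCCCCO)c2cccnc2n1` is reported only as a limit in this assay, where compound 2 gives > 100000 nM. For compound 2 this is the limit of > 100000 nM in this assay, at which 1 of the 2 values shown sits. The two compounds are not related by a single change, so nothing can be said of the gap between them beyond what the two values show; compound 1 stands as the sole fixed point of the set.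

Compound 3 `CCCCC[Se]c1nc(N)c2ccccc2n1` differs from compound 1 by one nitrogen atom in place of a group of 6 heavy atoms (5 carbon, 1 selenium; no ring), on an aromatic carbon. Among the compounds with values here, no measured pair isolates this change, so both its size and its direction remain open. Given that compound 1 already sits at 65700 nM, the expectation for compound 3 is a step of a 1.3-fold higher number from compound 1 to compound 3 (0.11 log units; within the scatter) in this assay, most likely toward weaker growth inhibition or none beyond the scatter. The estimated value for compound 3 in this assay is 85000 nM, within 30000 nM to 250000 nM. Measurement pending.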

Compound 3, concentration for 50% growth inhibition: 34800 nM
Compound 3: the middle estimate sits 2.4-fold (0.39 log units) above what was measured; measured number inside the range.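

In this assay, amino in place of the group of 6 heavy atoms (5 carbon, 1 selenium), on the aromatic carbon next to the ring nitrogen, gives a 1.9-fold lower number from compound 1 to compound 3 (0.28 log units; within the scatter). Going by these compounds alone, this is the first pair that isolates a change at this position, and it shows that removing this group and its selenium atom while adding the amino hydrogen-bond donor and acceptor produces no step beyond the scatter, so the read-out at this position does not depend on the group of 6 heavy atoms. No measurement shown bears on why the step is this small, so no cause can be assigned to it.

It remains open whether a different group at this position, such as a dimethylamino group, a hydroxyl or a shorter alkyl chain joined through selenium, would move the number beyond the scatter, since amino is the only replacement shown. The selenium-linked chain kept in both compounds also remains unprobed, and a replacement of it by a sulfur-linked pentyl chain or by an amine would test whether growth inhibition on these cells depends on that group.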